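Amino for hydroxy on two related cores

A few compounds are considered here, and "the series" means these few. Any claim that something is new, unique, unknown or untested is made for them only; others in the source may bear on it.

Compound 1 `Oc1ccc(/C=C/c2ccccc2O)cc1` and compound 3 `COc1ccc(/C=C/c2cccc(O)c2)cc1` carry different cores; the difference between the two cores is not broken down here. In a functional assay on HT-29 cells (Homo sapiens) for inhibition, read by MTT assay, with a stated time of 2 days (a lower number here means a stronger inhibitor, a higher number a weaker inhibitor), compound 1 gives 22 ug/mL. In this assay compound 3 gives 22 ug/mL, level with compound 1 at the digits shown, so the two fall within the usual scatter of each other.

Compound 2 `Nc1ccccc1/C=C/c1ccc(O)cc1` is made from compound 1 by the change (amino in place of hydroxy on an aromatic carbon). In this assay compound 2 gives > 100 ug/mL, which is a limit of the assay and not a number. The value of compound 2 sits at the limit of > 100 ug/mL in this assay, at which 1 of the 3 values shown sits. The step of an at least 4.5-fold higher number from compound 1 to compound 2 (0.65 log units; beyond the scatter) is accordingly a lower bound on the loss.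

Compound 4 `COc1ccc(/C=C/c2cccc(N)c2)cc1` is not yet measured. It is made from compound 3 by amino in place of hydroxy on an aromatic carbon. This is the same kind of change as from compound 1 to compound 2, but not the same: in compound 2 the amino sits ortho to a group of 9 heavy atoms, in compound 4 it sits meta to a large group. Going by the values given here, only one measured instance of this change exists, and it ends at a limit, so the size of the step is uncertain. The expected step of a 3.6-fold higher number from compound 3 to compound 4 (0.56 log units; beyond the scatter) is set beside an at least 4.5-fold higher number from compound 1 to compound 2 (0.65 log units; beyond the scatter) as a loss of similar kind, with real weight on a limit as the outcome. Compound 4 is thus estimated at 80 ug/mL, spanning 25 ug/mL to 200 ug/mL.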

Compound 4, half-maximal inhibitory concentration: 16.3 ug/mL
Compound 4: the middle estimate sits 4.9-fold (0.69 log units) above what was measured; measured number outside the range, below it.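

In this assay, amino in place of hydroxy on an aromatic carbon gives a 1.3-fold lower number from compound 3 to compound 4 (0.13 log units; within the scatter), so on the core of compound 3 the change leaves no readable mark, and the loss seen on the core of compound 1 does not carry over to this second core: the same change on two cores in this assay, an at least 4.5-fold higher number (0.65 log units; beyond the scatter) from compound 1 to compound 2 and a 1.3-fold lower number (0.13 log units; within the scatter) from compound 3 to compound 4, at least 6.1-fold (0.78 log units) apart, beyond the scatter of two such steps. The value of compound 2, > 100 ug/mL, is a limit of the assay and not a number: the limit of > 100 ug/mL in this assay, at which 1 of the 4 values shown sits. Going by these compounds alone, these two pairs show only that the step from this change is not of one size across the two cores; they do not show which difference between the cores sets the steps apart, and with one pair per core they say nothing about a third core.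

Still open, going by these compounds, is how a dimethylamino group or a carboxylic acid would read in place of the hydroxy on either core. Also open, on these data alone, is whether amino placed elsewhere on the ring of compound 4 would stay level with the hydroxy of compound 3 or would fall away as on the core of compound 1.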